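From 3-methylphenyl to 4-methylphenyl: a small expected step

The source may report more compounds than this note shows. Statements on the series, on what has been measured and on what is new or still open speak of the compounds shown alone.

Compound 1 `COc1cc2ncnc(Nc3ccc(NC(=O)c4ccccc4C)cc3)c2cc1OC` gives 21000 nM here
Compound 2 `COc1cc2ncnc(Nc3ccc(NC(=O)c4cccc(C)c4)cc3)c2cc1OC` gives 13000 nM here

Both numbers come from a functional assay on MCF7 cells (Homo sapiens) for inhibition, read by MTT assay (on this read-out lower numbers stand for stronger inhibition and higher numbers for weaker inhibition), and are read the same way. Compound 2 sits at 13000 nM and stands level with compound 1. The gap between them lies within the scatter of repeated measurements, so neither can be ranked above the other.

Compound 3 `COc1cc2ncnc(Nc3ccc(NC(=O)c4ccc(C)cc4)cc3)c2cc1OC` has not yet been measured. Its difference from compound 2 is small: 4-methylphenyl in place of 3-methylphenyl on a carbonyl carbon. Among the compounds with values here, one measured step bears on this change, with 3-methylphenyl in place of 2-methylphenyl on the same carbonyl carbon, and it shows a 1.6-fold lower number from compound 1 to compound 2 (0.21 log units; within the scatter) and nothing larger. With that single step as the guide, no step beyond the scatter is expected in this assay and no direction can be favoured. The estimate amounts to an expected 1.1-fold higher number from compound 2 to compound 3 (0.03 log units; within the scatter) and no more. One step is thin evidence, so the range stays wide. Compound 3 is expected at 14000 nM with an estimated range from 6500 nM to 30000 nM for a single measurement.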

Compound 3, half-maximal inhibitory concentration: 19000 nM
Estimate against measurement, compound 3: 1.4-fold (0.13 log units) below; the range from low to high includes it.
By their numbers in this assay, from the lowest: compounds 2, 3 and 1 (each within the scatter of the next).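

In this assay the methyl group can now be compared at all three places shown on the phenyl ring, and the change to 4-methylphenyl on the carbonyl carbon gives a 1.5-fold higher number from compound 2 to compound 3 (0.16 log units; within the scatter) and, counted from the other starting point, a 1.1-fold lower number from compound 1 to compound 3 (0.04 log units; within the scatter) as well. Together with the earlier step, this means that no pair among compound 1, compound 2 and compound 3 can be told apart, so within these three compounds the place of the methyl group on this ring shows no measurable effect on the number. No separate measurement is available that says why these numbers lie so close together.

These compounds differ only in where one methyl group sits, so they cannot tell whether a different group on this ring would move the number beyond the scatter. From the compounds shown here alone, a methoxy group, a chlorine atom or an amine on this ring, a longer chain such as ethyl in place of methyl, and a plain phenyl group with no methyl at all all remain open.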